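Replacing 4-fluorophenyl with 2-phenylethenyl in compound 2

This account rests on a few compounds, and the source may have more. Where it says the series, first, only, none or still open, it means among the compounds named here.

In a functional assay on HCT-116 cells (Homo sapiens) for antiproliferative activity, with a stated time of 72 h (on this read-out higher numbers stand for weaker inhibition and lower numbers for stronger inhibition), compound 2 `Nc1ncnn2c([C@@H]3O[C@H](CO)[C@@H](O)[C@H]3O)cc(-c3ccc(F)cc3)c12` gives 42500 nM, the higher of the two actual numbers in the series. Compound 3 `Nc1ncnn2c([C@@H]3O[C@H](CO)[C@@H](O)[C@H]3O)cc(-c3ccoc3)c12` gives 1400 nM, and the gap is large: a 30-fold lower number from compound 2 to compound 3 (1.48 log units; beyond the scatter). Compound 1 `Nc1ncnn2c([C@@H]3O[C@H](CO)[C@@H](O)[C@H]3O)cc(C#Cc3ccc(F)cc3)c12` gives > 100000 nM, which is a limit of this assay and not a number.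

Compound 4 `Nc1ncnn2c([C@@H]3O[C@H](CO)[C@@H](O)[C@H]3O)cc(/C=C/c3ccccc3)c12` differs from compound 2 by 2-phenylethenyl in place of 4-fluorophenyl on an aromatic carbon.

For the measured compounds named here, the closest precedent is the ethynyl-linked compound 1, the only measured member with a linker before its aryl ring. Going by the values given here, its step, an at least 2.3-fold lower number from compound 1 to compound 2 (0.37 log units; beyond the scatter), suggests that such a linker does not help, though only one pair supports this. The furan-3-yl result, an at least 71-fold lower number from compound 1 to compound 3 (1.85 log units; beyond the scatter), shows that this position can move the read-out strongly, so a wide range is warranted. Among the compounds with values here, no measured step isolates the loss of fluorine or the double bond itself.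

A small shift towards a higher number is therefore expected, probably not beyond the scatter, and a limit reading would be unsurprising. The expected change is a 1.4-fold higher number from compound 2 to compound 4 (0.15 log units; within the scatter). For compound 4 the estimated value is 60000 nM, with an expected range of 12000 nM to 100000 nM.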

Compound 4, half-maximal inhibitory concentration: 4800 nM
Compound 4: middle estimate off by 13-fold (1.10 log units), on the high side; the measured number lies below the stated range.
By their numbers in this assay, from the lowest: compound 3; then compound 4; then compound 2. At a limit, above all of these: compound 1.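

In this assay, a linker before the aryl ring on this aromatic carbon does not by itself raise the number: 2-phenylethenyl in place of 4-fluorophenyl gives an 8.9-fold lower number from compound 2 to compound 4 (0.95 log units; beyond the scatter), so the ranking of compound 1 against compound 2 does not carry over to a double-bonded linker. A carbon-only aromatic ring on a double bond still does not reach furan-3-yl, with a 3.4-fold higher number from compound 3 to compound 4 (0.54 log units; beyond the scatter), and compound 3 keeps the lowest number of the series, its steps to all the others being beyond the scatter. The change from 2-(4-fluorophenyl)ethynyl to 2-phenylethenyl gives an at least 20-fold lower number from compound 1 to compound 4 (1.31 log units; beyond the scatter), a step that holds only as a bound since one end of it is a limit: the limit of > 100000 nM in this assay, at which 1 of the 4 values shown sits.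

No pair shown separates the double bond from the loss of fluorine, so these two changes remain joined in the step from 4-fluorophenyl. Also open, as far as these compounds go, is whether an amine on the phenyl ring of 2-phenylethenyl, or a longer chain in place of the double bond, would keep the number near that of compound 4 or move it towards that of compound 3.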